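Swapping a methoxy for an amino on the side chain

The compounds below may be only part of what the source reports. "The series", "measured", "known", "first", "only" and "open" are said of these compounds alone.

Going by the values given here, compound 1 `COCCC1Sc2nnc(-c3cc(-c4ccccc4)n[nH]3)n2N=C1c1ccc(OC)cc1` is the stronger of the two compounds measured so far in a functional assay on CAL-33 cells (Homo sapiens) for inhibition; a lower number here means a stronger inhibitor of growth, a higher number a weaker inhibitor of growth. In this assay compound 1 gives 40 nM, the lowest of the two numbers recorded. Among the compounds with values here, the only other measured compound, compound 2 `CC1Sc2nnc(-c3cc(-c4ccc(F)cc4)n[nH]3)n2N=C1c1ccccc1`, differs from compound 1 in more than one place. In this assay compound 2 gives 36300 nM, a far higher number that lies well beyond the scatter of repeat measurements.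

Compound 3 `COc1ccc(C2=Nn3c(nnc3-c3cc(-c4ccccc4)n[nH]3)SC2CCN)cc1` has not yet been measured. It keeps the shared core of compound 1 and changes only the side chain, as follows: amino in place of methoxy on a saturated chain carbon, two bonds along the chain from a saturated ring carbon.

Within the data shown here, no measured pair of compounds shows this single change, so there is no recorded step on which to lean. Because compound 1 already stands at 40 nM, the expectation is that compound 3 stays in the same broad region, with a step from compound 1 to compound 3 estimated at a 2.0-fold higher number from compound 1 to compound 3 (0.30 log units; within the scatter), a small shift that may not exceed the scatter. For compound 3 in this assay the estimated value is 80 nM, with a likely range from 20 nM to 400 nM.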

Compound 3, concentration for 50% growth inhibition: 2500 nM
For compound 3 the middle estimate is 31-fold (1.49 log units) below the measured one; measured number outside the range, above it.
By their numbers in this assay, from the lowest: compound 1; then compound 3; then compound 2.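

In this assay, the end of this side chain proves to be far from a neutral spot: amino in place of methoxy, on a saturated chain carbon, two bonds along the chain from a saturated ring carbon, gives a 63-fold higher number from compound 1 to compound 3 (1.80 log units; beyond the scatter), a large step beyond the usual scatter. This is the first single-place change among the compounds shown, and it links a small exchange, with methoxy bringing no hydrogen-bond donor and amino bringing one, to much weaker growth inhibition on an otherwise unchanged structure. Nothing available explains why the swap has so large an effect.

The compounds shown do not tell whether the weaker inhibition comes from adding the amino or from losing the methoxy, and a hydroxyl or a dimethylamino at the same place would help to separate those two readings. From the compounds shown here alone, it also remains open whether a longer chain ending in an amine, or a carboxylic acid at this place, would follow the same trend, and whether this step would have the same size on a different core.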